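The source may hold more compounds than are shown below. What is called first, only, known or untested is meant among the compounds shown, and "the series" means these compounds.

Working notes on the series.

Three members of the series have been measured so far. Compound 1 `CCOc1ccccc1-c1ccc(-c2nc3cnccc3c(N[C@@H]3CCOC3=O)c2C#N)cc1` gives 2.7 in a physicochemical assay for lipophilicity, read by HPLC, at pH 7.5; a lower number here means a more polar compound, a higher number a more lipophilic compound. Compound 2 `CC[C@@H](Nc1c(C#N)c(-c2ccc(-c3ccc(F)cc3)cc2)nc2cnccc12)C(N)=O` gives 2.7 in this assay, level with compound 1 at the digits shown, the two standing together at the lower of the two levels seen. Compound 3 `CCOc1ccccc1-c1ccc(-c2nc3cncc(Cl)c3c(N[C@H](CC)C(N)=O)c2C#N)cc1` gives 3.7 in this assay, a number a full unit higher than compound 2 and beyond the scatter of repeated measurements; compound 3 differs from compound 2 in more than one place, so no single change can be read from that gap.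

Compound 4 `CC[C@@H](Nc1c(C#N)c(-c2ccc(-c3ccc(Cl)cc3)cc2)nc2cnccc12)C(N)=O` is not yet measured in this assay. It differs from compound 2 in one place only: chloro in place of fluoro on an aromatic carbon. Within the data shown here, no measured pair shows this same exchange, so its size here is not known from the data. The expected step from compound 2 to compound 4 is a small rise, a number 0.40 log units higher from compound 2 to compound 4 (beyond the scatter), at about the edge of the usual scatter. On that basis compound 4 is estimated at 3.1 in this assay, with a range from 2.7 to 3.5.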

Compound 4, distribution coefficient: 3.1
Compound 4: the middle estimate sits on the measured number at the digits printed; measured number inside the range.
By their numbers in this assay, from the lowest: compounds 1 and 2 (each within the scatter of the next); then compound 4; then compound 3.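

In this assay, among these compounds, the exchange of fluoro for chloro gives a number 0.40 log units higher from compound 2 to compound 4 (beyond the scatter), the first step that can be tied to a single place. Compound 1, compound 2 and compound 3 differ from one another in more than one place and gave no such reading, whereas this pair shows that the number in this series can move beyond the scatter with one heavy atom exchanged for another on an aromatic carbon para to a large group, with no hydrogen-bond donor, hydrogen-bond acceptor, ring or net charge entering or leaving. Nothing at hand bears on what lies behind this step, so it stands as an observation only.

The compounds shown carry only fluoro and chloro at this place, so it remains open how a methyl, a trifluoromethyl or an amine on the same carbon would stand in this assay. On these data alone, the exchange is also seen in this one pair only, and whether a step of this size carries over to other members remains open.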